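A few compounds are considered here, and "the series" means these few. Any claim that something is new, unique, unknown or untested is made for them only; others in the source may bear on it.

Working notes on the series. The shared core is that of compound 1 `CC(=O)Nc1ccc(Cc2noc(CCC(=O)Nc3ccccc3)n2)cc1`. Going by the values given here, in a functional assay on the whole organism (strain C57BL/6) for inhibition, with Mus musculus as the target, read by paw edema, with stated times of 1 h and 4 h, at a dose of 100 mg/kg by the oral route (on this read-out lower numbers stand for less inhibition and higher numbers for more inhibition at the one dose given (going by the name of the read-out)), compound 1 gives 34.2%, the lowest of the three numbers measured so far. Compound 2 `COc1ccc(NC(=O)CCc2nc(Cc3ccc(NC(C)=O)cc3)no2)cc1` gives 49.3%, and compound 3 `CC(=O)Nc1ccc(Cc2noc(CCC(=O)Nc3ccccc3F)n2)cc1` gives 67.1%. Both measured steps from compound 1 alter the aryl group on the amide-type nitrogen: a number 15.1 percentage points higher from compound 1 to compound 2 (beyond the scatter) with methoxy in place of hydrogen on an aromatic carbon, and a number 32.9 percentage points higher from compound 1 to compound 3 (beyond the scatter) with fluoro in place of hydrogen on an aromatic carbon. The step of a number 17.8 percentage points higher from compound 2 to compound 3 (beyond the scatter), 2-fluorophenyl in place of 4-methoxyphenyl on an amide-type nitrogen, separates those two.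

Compound 4 `CC(=O)Nc1ccc(Cc2noc(CCC(=O)NCc3ccccc3)n2)cc1` is not yet measured. It differs from compound 1 by benzyl in place of phenyl on an amide-type nitrogen, the same difference cut one bond further out reading anilino to benzylamino. Among the compounds with values here, no measured step exchanges the group on the amide-type nitrogen in this way; the steps from compound 1 show only that this end of the molecule is where the numbers have moved, each time upward and beyond the scatter. Since the direction for compound 4 cannot be read from them, the step expected is a number 3.8 percentage points higher from compound 1 to compound 4 (within the scatter), small and uncertain. Compound 4 is therefore estimated at 38%, with a range from 18% to 60%.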

Compound 4, a percentage reported as inhibition, in the whole organism at one dose (the size of the read-out at that dose, not a potency): 76.7%
Compound 4: middle estimate off by 38.7 percentage points, on the low side; measured number above the stated range.
By their numbers in this assay, from the lowest: compound 1; then compound 2; then compounds 3 and 4 (each within the scatter of the next).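

Benzyl in place of phenyl on an amide-type nitrogen gives a number 42.5 percentage points higher from compound 1 to compound 4 (beyond the scatter) in this assay, so a change in the group attached to this nitrogen can move the number as much as the ring substitutions seen so far, with no substituent on the aromatic ring of the entering group. Set against the two substituted anilides, the benzyl compound gives two different outcomes: a number 27.4 percentage points higher from compound 2 to compound 4 (beyond the scatter), but a number 9.6 percentage points higher from compound 3 to compound 4 (within the scatter), so in this assay the benzyl and 2-fluorophenyl groups are not separated, and benzyl is not shown to surpass every group tried at this position. The data at hand offer no explanation for the size of the step from the phenyl to the benzyl compound.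

The compounds shown leave open whether a 2-phenylethyl group on the same nitrogen would carry the number further or lose it. They also leave open whether fluoro or methoxy on the benzyl ring would add to the benzyl result, or whether the two changes would fail to combine.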